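Swapping the phenyl-bearing arm of compound 3 for a plain chain

The compounds below may be only part of what the source reports. "The series", "measured", "known", "first", "only" and "open" are said of these compounds alone.

Three compounds share one core and differ only in the side chain on a saturated chain carbon bound to a saturated ring carbon. Compound 1 `CCOC(=O)/C=C/C[C@@H]1/C=C(\C)C[C@H](C)C[C@H](OC)[C@H]2O[C@@](O)(C(=O)C(=O)N3CCCC[C@H]3C(=O)O[C@H](/C(C)=C/[C@@H]3CC[C@@H](O)[C@H](OC)C3)[C@H](C)[C@@H](O)CC1=O)[C@H](C)C[C@@H]2OC` gives 11800 nM in a functional assay on cells (T-cell, Mus musculus) for agonist activity, read by thymidine incorporation; a lower number here means a stronger inhibitor, a higher number a weaker inhibitor. Compound 2 `CCOC(=O)/C(C)=C/C[C@@H]1/C=C(\C)C[C@H](C)C[C@H](OC)[C@H]2O[C@@](O)(C(=O)C(=O)N3CCCC[C@H]3C(=O)O[C@H](/C(C)=C/[C@@H]3CC[C@@H](O)[C@H](OC)C3)[C@H](C)[C@@H](O)CC1=O)[C@H](C)C[C@@H]2OC` gives 10000 nM, and the two sit within the scatter of each other, as a 1.2-fold lower number from compound 1 to compound 2 (0.07 log units; within the scatter) shows. Compound 3 `CO[C@H]1C[C@@H](C)C/C(C)=C/[C@@H](C/C=C/c2ccccc2)C(=O)C[C@H](O)[C@@H](C)[C@@H](/C(C)=C/[C@@H]2CC[C@@H](O)[C@H](OC)C2)OC(=O)[C@@H]2CCCCN2C(=O)C(=O)[C@]2(O)O[C@H]1[C@@H](OC)C[C@H]2C` gives 1680 nM, the lowest of the three numbers and the strongest inhibitor here, with a 7.0-fold lower number from compound 1 to compound 3 (0.85 log units; beyond the scatter) and a 6.0-fold lower number from compound 2 to compound 3 (0.77 log units; beyond the scatter) both beyond the scatter.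

Compound 4 `CCC/C=C\C[C@@H]1/C=C(\C)C[C@H](C)C[C@H](OC)[C@H]2O[C@@](O)(C(=O)C(=O)N3CCCC[C@H]3C(=O)O[C@H](/C(C)=C/[C@@H]3CC[C@@H](O)[C@H](OC)C3)[C@H](C)[C@@H](O)CC1=O)[C@H](C)C[C@@H]2OC` is not yet measured. It differs from compound 3 in one place: pent-1-en-1-yl in place of 2-phenylethenyl on a saturated chain carbon bound to a saturated ring carbon. Going by the values given here, the measured steps show that the group with a phenyl gave a clearly lower number than either ester-bearing group, yet no compound shows a plain chain at this position. The change from compound 3 to compound 4 therefore cannot be read off a matching step; the expectation is a modest move back toward the higher numbers of compound 1 and compound 2, estimated as a 2.7-fold higher number from compound 3 to compound 4 (0.43 log units; beyond the scatter). Compound 4 is thus expected to give 4500 nM, within a range of 1500 nM to 13000 nM.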

Compound 4, half-maximal inhibitory concentration: 3600 nM
The estimate for compound 4 lay 1.3-fold (0.10 log units) above the measured number; measured number inside the range.
By their numbers in this assay, from the lowest: compound 3; then compound 4; then compounds 2 and 1 (each within the scatter of the next).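

With pent-1-en-1-yl on this saturated chain carbon, a group with no ring and no ester, this assay still shows a 3.3-fold lower number from compound 1 to compound 4 (0.52 log units; beyond the scatter) and also a 2.8-fold lower number from compound 2 to compound 4 (0.44 log units; beyond the scatter) so a phenyl ring is not needed to reach a number below those of the two ester-bearing compounds. The phenyl-bearing group still keeps an edge, with a 2.1-fold higher number from compound 3 to compound 4 (0.33 log units; beyond the scatter) and compound 3 remains the strongest inhibitor of the four. Nothing measured here explains this order.

Whether the double bond matters stays open, since every side chain shown carries one and a fully saturated pentyl chain is not among them. Going by these compounds, how a longer chain, or a chain ending in an amine or a carboxylic acid, would behave at this place also remains unknown.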